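A few compounds are considered here, and "the series" means these few. Any claim that something is new, unique, unknown or untested is made for them only; others in the source may bear on it.

Three compounds here share one core and differ only in the methoxy groups on one of their aromatic rings: compound 1 `COc1ccc(CCCc2ccc(OC)c(OC)c2)c(O)c1`, compound 2 `COc1ccc(CCCc2ccc(OC)cc2OC)c(O)c1` and compound 3 `COc1ccc(CCCc2ccc(OC)cc2O)cc1`. In an ADME assay on RAW264.7 cells (Mus musculus) for cytotoxicity, read by MTT assay, with a stated time of 24 h, tested at 2.5 ug/mL (on this read-out higher numbers stand for a weaker effect at the one concentration tested and lower numbers for a stronger effect), compound 1 gives 91.7%, compound 2 gives 97.7% and compound 3 gives 96.8%. Compound 2 thus stands within the scatter of both others, since the step of a number 5.1 percentage points higher from compound 1 to compound 3 (within the scatter) and the step of a number 0.9 percentage points lower from compound 2 to compound 3 (within the scatter) are each small.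

Compound 4 `COc1ccc(CCCc2ccc(OC)c(OC)c2OC)c(O)c1` differs from compound 2 by methoxy in place of hydrogen on an aromatic carbon. Both measured steps swapped a methoxy for hydrogen and moved the number only within the scatter, so the reverse change is expected to do the same in this assay. Compound 4 is therefore estimated at 96%, between 86% and 100%, an expected step of a number 1.7 percentage points lower from compound 2 to compound 4 (within the scatter).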

Compound 4, a percentage reported as activity, at one concentration (the size of the read-out at that concentration, not a potency): 95.5%
Compound 4: middle estimate off by 0.5 percentage points, on the high side, and the stated range covers the measured number.
By their numbers in this assay, from the lowest: compounds 1, 4, 3 and 2 (each within the scatter of the next).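

Placing a methoxy on this aromatic carbon, ortho to two methoxy groups, can now be read as an addition in this assay, and it gives a number 2.2 percentage points lower from compound 2 to compound 4 (within the scatter) and, at another place on the same ring, a number 3.8 percentage points higher from compound 1 to compound 4 (within the scatter). Removing a methoxy at one place on the ring also compares closely across two cores: the same change on two cores in this assay, a number 5.1 percentage points higher (within the scatter) from compound 1 to compound 3 and a number 2.2 percentage points higher (within the scatter) from compound 4 to compound 2, 2.9 percentage points apart, within the scatter of two such steps The same holds for the other place: the same change on two cores in this assay, a number 0.9 percentage points lower (within the scatter) from compound 2 to compound 3 and a number 3.8 percentage points lower (within the scatter) from compound 4 to compound 1, 2.9 percentage points apart, within the scatter of two such steps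

Still open, as far as these compounds go, is whether an amine or a carboxylic acid on this carbon would shift the number beyond the scatter. A longer chain such as butoxy poses the same question.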